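The compounds below may be only part of what the source reports. "The series", "measured", "known", "first", "only" and "open" are said of these compounds alone.

Measured so far in a functional assay on HeLa cells (Homo sapiens) for cytotoxicity, read by MTT assay, with a stated time of 24 h; on this read-out higher numbers stand for weaker inhibition and lower numbers for stronger inhibition:

Compound 1 `C=CC1=C(C(=O)Nc2ccc(C)cc2)C(c2ccc(F)cc2)OC1`; compound 1 gives > 100000 nM, which is a limit of the assay, not a number.
Compound 2 `C=CC1=C(C(=O)Nc2ccc(OCC)cc2)C(c2ccc(F)cc2)OC1`; compound 2 gives > 100000 nM, again a limit.
Compound 3 `C=CC1=C(C(=O)Nc2ccc(C)cc2)C(c2ccc(OC)cc2)OC1`; compound 3 gives > 100000 nM, again a limit.

Compound 1 therefore stands only at the assay limit, and no ordering among the three is possible. The step from compound 1 to compound 2 a step that the two limits leave unreadable from compound 1 to compound 2 and the step from compound 1 to compound 3 a step that the two limits leave unreadable from compound 1 to compound 3 are both unreadable, because of the limit of > 100000 nM in this assay, at which 3 of the 3 values shown sit.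

Compound 4 `C=CC1=C(C(=O)NCCCCC)C(c2ccc(F)cc2)OC1` differs from compound 1 at the amide nitrogen: pentyl in place of 4-methylphenyl on an amide-type nitrogen. Among the measured compounds shown here, none of the measured steps touches that position; the two steps that exist concern substituents on the aromatic rings, and neither gives a readable size. The only bearing they have is that every change tried so far left the compounds at the limit. The expected step from compound 1 to compound 4 in this assay is therefore a number no higher from compound 1 to compound 4 (the limit leaves the size open), which is an expectation without a readable precedent. For compound 4 the estimated value is 100000 nM, with a range from 30000 nM to 300000 nM, and a further limit reading is considered the most likely outcome.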

Compound 4, half-maximal inhibitory concentration: > 100000 nM
Compound 4: a limit, no number; the forecaster's own chance of this, stated with the estimate: 80%; the middle value sits exactly at the limit.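

In this assay no size can be read for the exchange of 4-methylphenyl for pentyl between compound 1 and compound 4, because both compounds stand at the limit: the limit of > 100000 nM in this assay, at which 4 of the 4 values shown sit.

The compounds shown leave open how these four rank among themselves, and which change to the shared core would give a readable value.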